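The source may report more compounds than this note shows. Statements on the series, on what has been measured and on what is new or still open speak of the compounds shown alone.

Measured compounds in a functional assay on HepG2 cells (Homo sapiens) for cytotoxicity, read by MTT assay, with a stated time of 48 h; on this read-out higher numbers stand for weaker inhibition and lower numbers for stronger inhibition:
compound 1, `[O-][S+](CCC(F)=C(F)F)c1ncc(-c2ccncc2)s1`, reported as a limit of the assay: > 120000 nM
compound 2, `FC(F)=C(F)CCSc1nccs1`, reported as a limit of the assay: > 120000 nM
compound 3, `FC(F)=C(F)CCSc1ncc(-c2ccncc2)s1`, reported as a limit of the assay: > 120000 nM

All three results sit at the same point, namely (the limit of > 120000 nM in this assay, at which 3 of the 3 values shown sit). Going by the values given here, the only pair that differs in one place is compound 3 and compound 2, where the change is hydrogen in place of pyridin-4-yl on an aromatic carbon; the step in this assay is a step that the two limits leave unreadable from compound 3 to compound 2, so its size cannot be read. Compound 1 and compound 3 differ in more than one place; the difference between the two cores is not broken down here, and the two values show only that both are limits of the assay.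

Compound 4, `[O-][S+](CCC(F)=C(F)F)c1nccs1`, has not been measured. Relative to compound 1 the change is hydrogen in place of pyridin-4-yl on an aromatic carbon. This is the same kind of change as that from compound 3 to compound 2, but not the same: around the place, the ring atom two ring bonds away bears a group of 9 heavy atoms in compound 1 and a group of 8 heavy atoms in compound 3.

For compound 4 the expected step in this assay is a step that the limit leaves unreadable from compound 1 to compound 4, which rests on a step that the two limits leave unreadable from compound 3 to compound 2 being unreadable and on (the limit of > 120000 nM in this assay, at which 3 of the 3 values shown sit), where every shown value sits. Compound 4 is therefore estimated at 200000 nM, expected between 120000 nM and 1000000 nM, most likely returned as a limit rather than a number.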

Compound 4, half-maximal inhibitory concentration: > 120000 nM
Compound 4: no number, only a limit (the forecaster's own chance of this, stated with the estimate: 90%); the middle value lies beyond the limit too.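

No new step can be read for compound 1 and compound 4 in this assay: both are reported only as limits, so the replacement of pyridin-4-yl by hydrogen has no readable size, and the whole set sits at one point: the limit of > 120000 nM in this assay, at which 4 of the 4 values shown sit.

The compounds shown leave open how the four rank against one another and whether that replacement changes the read-out at all.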